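Swapping Chloro for Methyl on Compound 1

A few compounds are considered here, and "the series" means these few. Any claim that something is new, unique, unknown or untested is made for them only; others in the source may bear on it.

Compound 1 `Cc1nc(N(C)c2ccc([Se]C#N)c(Cl)c2)c2ccccc2n1` is the anchor of this small set. In a functional assay on HCT-116 cells (Homo sapiens) for inhibition, read by MTT assay, with a stated time of 48 h (a higher number here means a weaker inhibitor, a lower number a stronger inhibitor), compound 1 gives 12 nM, the lowest number of the three measured compounds, and its steps to both others lie beyond the scatter. The other two carry the same core but a different substitution pattern: compound 2 `COc1ccc(N(C)c2nc(C)nc3ccccc23)cc1OCCCCCC[Se]C#N` gives 6180 nM in this assay, and compound 3 `COc1ccc(N(C)c2nc(C)nc3ccccc23)cc1OCCCC[Se]C#N` gives 512 nM. Within the data shown here, the only measured step, a 12-fold lower number from compound 2 to compound 3 (1.08 log units; beyond the scatter), concerns the length of a saturated chain hanging from an oxygen on an aromatic ring. Among the measured compounds shown here, compound 1 stands well below both, but no measured step links it to either.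

Compound 4 `Cc1nc(N(C)c2ccc([Se]C#N)c(C)c2)c2ccccc2n1` differs from compound 1 in a single place: methyl in place of chloro on an aromatic carbon. For the measured compounds named here, no measured step covers an exchange of this kind; the one step available is a chain change and gives no guide to replacing one single-atom group by another on the ring. With nothing to point in either direction, a step no larger than the usual scatter is expected, so compound 4 is estimated at 20 nM, with a range from 5 nM to 80 nM. That estimate amounts to an expected 1.7-fold higher number from compound 1 to compound 4 (0.22 log units; within the scatter).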

Compound 4, half-maximal inhibitory concentration: 13 nM
Estimate against measurement, compound 4: 1.5-fold (0.19 log units) above; the range from low to high includes it.
By their numbers in this assay, from the lowest: compounds 1 and 4 (each within the scatter of the next); then compound 3; then compound 2.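

In this assay the exchange of chloro for methyl on this aromatic carbon, ortho to a group of 3 heavy atoms, gives a 1.1-fold higher number from compound 1 to compound 4 (0.03 log units; within the scatter) and so leaves the two compounds indistinguishable. Among these compounds, this is the first measured step on the ring itself rather than on a chain, and it shows that the low number of compound 1 does not require chloro, since methyl at the same place keeps the number in the same range. No measurement shown here explains why these two groups give such similar numbers.

Neither chloro nor methyl has a hydrogen-bond donor or acceptor, so the result says nothing about how far this tolerance extends to a different kind of group, such as an amine, a hydroxyl or a carboxylic acid, or to a longer chain such as propyl. It also leaves open whether the number would stay this low with plain hydrogen at this position, which would show whether the ring carbon needs any group at all.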